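Hydroxy in Place of Fluoro: An Expected Change in Potency

The source may report more compounds than this note shows. Statements on the series, on what has been measured and on what is new or still open speak of the compounds shown alone.

Measured compounds:
compound 1, `O=C(/C=C\Nc1ccc(Cl)cc1)c1cn(-c2ccccc2)nc1-c1ccc(Cl)cc1`: 4650 nM
compound 2, `COc1cc(-c2nn(-c3ccccc3)cc2C(=O)/C=C\Nc2ccc(F)cc2)cc(OC)c1OC`: 12500 nM

Of the compounds shown here, two have been measured in a functional assay on HT-29 cells (Homo sapiens) for antiproliferative activity, read by MTT assay, with a stated time of 48 h; a higher number here means a weaker inhibitor, a lower number a stronger inhibitor. Compound 1 gives 4650 nM. Compound 2 gives 12500 nM, the higher of the two numbers, and its gap to compound 1 lies beyond the usual scatter of the measurement. Within the data shown here, no pair of measured compounds differs in only one place, so no single step has been observed.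

Compound 3, `COc1cc(-c2nn(-c3ccccc3)cc2C(=O)/C=C\Nc2ccc(O)cc2)cc(OC)c1OC`, has not yet been measured. It differs from compound 2 in one place: hydroxy in place of fluoro on an aromatic carbon. Among the measured compounds shown here, no measured pair shows this change, so its size is unknown from the data. The step from compound 2 to compound 3 is expected to be a 1.3-fold lower number from compound 2 to compound 3 (0.10 log units; within the scatter), which is none beyond the scatter, with at most a slight drift toward a lower number. Compound 3 is therefore estimated at 10000 nM, between 3000 nM and 40000 nM.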

Compound 3, half-maximal inhibitory concentration: 2500 nM
The estimate for compound 3 lay 4.0-fold (0.60 log units) above the measured number, outside the stated range (below it).
By their numbers in this assay, from the lowest: compounds 3 and 1 (each within the scatter of the next); then compound 2.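

In this assay, placing hydroxy in place of fluoro on the six-membered aromatic ring of carbon only, para to a large group, gives a 5.0-fold lower number from compound 2 to compound 3 (0.70 log units; beyond the scatter) and this step lies beyond the scatter. The earlier compounds shown here differ in more than one place and could not single out any one position, whereas this step shows that the number responds to the group at this one. Nothing in the data at hand accounts for the size or direction of this step.

The compounds shown leave open whether this lower number is particular to hydroxy or would also appear with another group here, such as an amine or a carboxylic acid. They also leave open whether the same change would give a step of similar size in the setting of compound 1, which carries chloro at this position and differs elsewhere as well.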